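This account rests on a few compounds, and the source may have more. Where it says the series, first, only, none or still open, it means among the compounds named here.

Compound 1 (`COc1cccc(-c2nn(-c3ccccc3)cc2C(Nc2nc3ccccc3s2)c2c(O)ccc3ccccc23)c1`): 14900 nM
Compound 2 (`COc1ccc2nc(NC(c3cn(-c4ccccc4)nc3-c3ccc(F)cc3)c3c(O)ccc4ccccc34)sc2c1`): 4630 nM
Compound 3 (`Oc1ccc2ccccc2c1C(Nc1nc2ccc(Cl)cc2s1)c1cn(-c2ccccc2)nc1-c1ccc(F)cc1`): 30100 nM

In a functional assay on HeLa cells (Homo sapiens) for antiproliferative activity, read by MTT assay, with a stated time of 48 h (a higher number here means a weaker inhibitor, a lower number a stronger inhibitor), compound 3 gives 30100 nM, the highest of the three numbers. Compound 1 lies nearest at 14900 nM, and compound 2 lies furthest at 4630 nM.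

Compound 4 (`O=[N+]([O-])c1ccc(-c2nn(-c3ccccc3)cc2C(Nc2nc3ccc(Cl)cc3s2)c2c(O)ccc3ccccc23)cc1`) has not yet been measured. It differs from compound 3 by the change from 4-fluorophenyl to 4-nitrophenyl: nitro in place of fluoro on an aromatic carbon.

For the measured compounds named here, no measured pair tests this change directly. Going by the values given here, the only measured step, a 6.5-fold higher number from compound 2 to compound 3 (0.81 log units; beyond the scatter), is a different swap, chloro in place of methoxy on an aromatic carbon. Among the compounds with values here, it shows only that a single swap can move the number modestly in this assay. A modest step is therefore expected, with either direction possible, leaning slightly to a lower number because compound 3 at 30100 nM already stands highest of the three. The expected step is a 1.7-fold lower number from compound 3 to compound 4 (0.22 log units; within the scatter), and it is uncertain. For compound 4 the estimated value is 18000 nM, with an expected range of 6000 nM to 50000 nM.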

Compound 4, half-maximal inhibitory concentration: 13400 nM
Compound 4: middle estimate off by 1.3-fold (0.13 log units), on the high side; measured number inside the range.
By their numbers in this assay, from the lowest: compound 2; then compounds 4 and 1 (each within the scatter of the next); then compound 3.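

In this assay, replacing 4-fluorophenyl with 4-nitrophenyl gives a 2.2-fold lower number from compound 3 to compound 4 (0.35 log units; beyond the scatter). For the compounds shown here, the earlier step concerned a different place, so this is the first sign that the substituent on this aromatic ring, para to a large group, can move the number beyond the scatter, here toward a lower value while the chloro group stays in place. No measurement available here offers an explanation for this step.

As far as these compounds go, a single pair tests this position, so it remains open how other groups there, such as an amine or a carboxylic acid, would compare with fluoro and nitro. From the compounds shown here alone, it is also open whether the same change from fluoro to nitro would move the number in the same direction with the methoxy group of compound 2 in place of chloro.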